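Bromo in place of 3-methylphenyl on the core of compound 3

This account rests on a few compounds, and the source may have more. Where it says the series, first, only, none or still open, it means among the compounds named here.

Compound 3 `Cc1cccc(-c2sc(N)c(C(=O)c3ccc(Cl)cc3)c2CC(C)(C)C)c1` gives 1% in an assay on CHO cells for displacement of a labelled ligand from adenosine receptor A1 (Homo sapiens), read by scintillation counting, tested at 10 uM (a lower number here means less inhibition, a higher number more inhibition at the concentration tested (going by the name of the read-out)), level with compound 1 `Cc1c(Br)sc(N)c1C(=O)c1ccc(Cl)cc1` at 1% and with compound 2 `CC(C)(C)Cc1c(-c2ccc(Cl)cc2)sc(N)c1C(=O)c1ccc(Cl)cc1` at 1%. Going by the values given here, the one step measured within the set, no change at the digits printed from compound 2 to compound 3 (within the scatter), is flat. Compound 4 `CC(C)(C)Cc1c(Br)sc(N)c1C(=O)c1ccc(Cl)cc1` differs from compound 3 by bromo in place of 3-methylphenyl on an aromatic carbon. Among the compounds with values here, no measured step covers this exact change; compound 1 also carries bromo on its core and sits at the same level as compound 3, so nothing in the numbers points to a shift in this assay. Compound 4 is therefore expected at 1%, with a range from -8% to 10%. The expected step of no change at the digits printed from compound 3 to compound 4 (within the scatter) is estimated to be none beyond the scatter.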

Compound 4, a percentage reported as inhibition, at one concentration (the size of the read-out at that concentration, not a potency): 1%
Estimate against measurement, compound 4: no gap at the digits printed; the measured number falls inside the stated range.
By their numbers in this assay, from the lowest: compounds 1, 2, 3 and 4 (each within the scatter of the next).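

Bromo in place of 3-methylphenyl gives no change at the digits printed from compound 3 to compound 4 (within the scatter) in this assay and bromo in place of 4-chlorophenyl gives no change at the digits printed from compound 2 to compound 4 (within the scatter) at this carbon next to the ring sulfur, so a small halogen and both aryl groups read alike here. With bromo held fixed, tert-butyl in place of hydrogen on the chain gives no change at the digits printed from compound 1 to compound 4 (within the scatter) and the neopentyl group adds nothing readable. No supporting data explain these flat readings. Going by these compounds, whether an amine or a carboxylic acid at this ring carbon would lift the reading stays open.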